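This account rests on a few compounds, and the source may have more. Where it says the series, first, only, none or still open, it means among the compounds named here.

In a functional assay on HCT-8 cells (Homo sapiens) for cytotoxicity (a lower number here means that less compound is needed, a higher number that more compound is needed for the effect), compound 2 `c1ccc(COc2cc(-c3ccccc3)nc3ccccc23)cc1` gives > 10 ug/mL, which is a limit of the assay and not a number. Compound 1 `CCOc1cc(-c2ccccc2)nc2ccccc12` gives > 10 ug/mL, likewise a limit. For the measured compounds named here, compound 3 `Oc1ccc2nc(-c3ccccc3)cc(O)c2c1` gives 7.75 ug/mL, the only true number so far.

Compound 4 `CC(C)Oc1cc(-c2ccccc2)nc2ccccc12` differs from compound 2 in one place: isopropyl in place of benzyl on an oxygen on an aromatic ring. In short, benzyloxy gives way to isopropoxy.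

Going by the values given here, the one measured step that bears on this change is a step that the two limits leave unreadable from compound 1 to compound 2, and it offers no size to carry over. What the series does show is the limit of > 10 ug/mL in this assay, at which 2 of the 3 values shown sit. Neither a direction nor a size beyond the scatter can therefore be argued from the data, and the expectation is that compound 4 stays with compounds 1 and 2 rather than moving away from them. The step expected is a step that the limit leaves unreadable from compound 2 to compound 4, an estimate with no readable size behind it.

Compound 4 is expected to give about 14 ug/mL, with an estimated range from 6 ug/mL to 30 ug/mL. A report of only a limit is the likeliest outcome.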

Compound 4, half-maximal effective concentration: 10 ug/mL
The estimate for compound 4 lay 1.4-fold (0.15 log units) above the measured number; measured number inside the range.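

In this assay, for the compounds shown here, compound 4 gives 10 ug/mL, the first true number for a compound with a group on this oxygen on an aromatic ring. Isopropyl in place of benzyl gives a number no higher from compound 2 to compound 4 (the limit leaves the size open), and the extra methyl on the chain gives a number no higher from compound 1 to compound 4 (the limit leaves the size open), so both steps have a direction that is capped but no readable size. The number therefore shows that isopropoxy does not take the series clearly away from the edge of what this assay reports: the limit of > 10 ug/mL in this assay, at which 2 of the 4 values shown sit.

The compounds shown leave open how far compounds 1 and 2 really lie from compound 4. They also leave open what an amine, a carboxylic acid or a longer chain on this oxygen would give.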